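Kinetic solubility notes on two measured analogues and one pending

The source may hold more compounds than are shown below. What is called first, only, known or untested is meant among the compounds shown, and "the series" means these compounds.

Compound 1 `COc1ccc(-c2cc(-c3cccc(S(C)(=O)=O)c3)cnc2N)cn1` and compound 2 `COc1ccc(-c2cc(-c3ccc(NS(C)(=O)=O)cc3)cnc2N)cn1` have both been run in a physicochemical assay for solubility, read by nephelometry, measured as kinetic solubility, at pH 2; on this read-out lower numbers stand for lower solubility and higher numbers for higher solubility. Compound 1 gives > 100 ug/mL, which is a limit of this assay. Compound 2 likewise gives > 100 ug/mL, again a limit rather than a number. Compound 2 thus stands at the limit, as summarised by the limit of > 100 ug/mL in this assay, at which 2 of the 2 values shown sit. Compound 3 `CNC(=O)c1ccc(-c2cnc(N)c(-c3ccc(OC)nc3)c2)cc1` differs from compound 2 by methylcarbamoyl in place of methanesulfonamido on an aromatic carbon. For the measured compounds named here, no measured step exists for this change; the expected step of a number no higher from compound 2 to compound 3 (the limit leaves the size open) is none beyond the scatter. Compound 3 is expected at 100 ug/mL, in the range 40 ug/mL to 200 ug/mL, most likely reported again as a limit.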

Compound 3, solubility: 50 ug/mL
For compound 3 the middle estimate is 2.0-fold (0.30 log units) above the measured one, and the stated range covers the measured number.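

Methylcarbamoyl in place of methanesulfonamido, on an aromatic carbon para to a large group, gives the first result in this assay that is a number and not a limit. The step is an at least 2.0-fold lower number from compound 2 to compound 3 (0.30 log units; that floor lies within the scatter), so a loss beyond the scatter is neither shown nor excluded. The true size of the step stays open: the limit of > 100 ug/mL in this assay, at which 2 of the 3 values shown sit.

Open, as far as these compounds go, is how a carboxylic acid or an amine at this place would read in this assay. Also open, from the compounds shown here alone, is whether a longer chain in place of the methyl of methylcarbamoyl would move the result.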